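The compounds below may be only part of what the source reports. "The series", "measured", "known", "first", "only" and "open" are said of these compounds alone.

Measured compounds:
- compound 1, `CCCCC(=O)NC(=S)Nc1nc2cc([N+](=O)[O-])ccc2s1`: in a functional assay on HeLa cells (Homo sapiens) for cytotoxicity, read by MTT assay, with a stated time of 24 h (on this read-out higher numbers stand for weaker inhibition and lower numbers for stronger inhibition), compound 1 has "not determined" (no result reported)
- compound 2, `O=C(NC(=S)Nc1nc2ccccc2s1)c1ccccc1`: compound 2 gives 57500 nM
- compound 3, `O=C(NC(=S)Nc1nc2cc([N+](=O)[O-])ccc2s1)N1CCOCC1`: compound 3 gives 54800 nM

Compound 3 holds the lower of the two numbers, with compound 2 its nearest neighbour; the gap between them lies within the scatter, so no order between compound 2 and compound 3 can be read from these two values. Compound 1 contributes no number.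

The next compound, compound 4 `O=C(NC(=S)Nc1nc2cc([N+](=O)[O-])ccc2s1)c1ccccc1`, follows from compound 3 by a single change: phenyl in place of morpholin-4-yl on a carbonyl carbon. For the measured compounds named here, no step between two measured compounds is available to calibrate this exchange, and the two measured values fall close together, giving no lever for a directional guess. The expectation is therefore a step from compound 3 to compound 4 of a 1.1-fold lower number from compound 3 to compound 4 (0.04 log units; within the scatter), that is, none beyond the scatter. Compound 4 is estimated at 50000 nM, with a range from 20000 nM to 150000 nM.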

Compound 4, half-maximal inhibitory concentration: 75100 nM
Estimate against measurement, compound 4: 1.5-fold (0.18 log units) below; low and high end bracket the measured number.
By their numbers in this assay, from the lowest: compounds 3, 2 and 4 (each within the scatter of the next).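

In this assay the exchange of morpholin-4-yl for phenyl on a carbonyl carbon now has a first measured size: the change gives a 1.4-fold higher number from compound 3 to compound 4 (0.14 log units; within the scatter) and so does not separate the two groups on this read-out. Nitro in place of hydrogen on an aromatic carbon also has its first step, with a benzoyl group present, and gives a 1.3-fold higher number from compound 2 to compound 4 (0.12 log units; within the scatter) so that this exchange likewise leaves the two compounds unresolved. No independent measurement is available to account for either result.

Going by these compounds, whether any other group on that carbonyl carbon, such as piperidin-1-yl, a phenyl carrying a carboxylic acid or a longer alkyl chain, would stand apart from phenyl and morpholin-4-yl remains open. Also open, on these data alone, is whether an amine in place of nitro on the aromatic carbon would give a step beyond the scatter.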